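From dimethylsulfamoyl to methylsulfonyl: estimating an unbound share

A few compounds are considered here, and "the series" means these few. Any claim that something is new, unique, unknown or untested is made for them only; others in the source may bear on it.

compound 1 `CN(C)S(=O)(=O)c1ccc(F)c(C#Cc2cc(Cl)ccc2OCC(=O)O)c1` - 0.009
compound 2 `Cc1ccc(S(=O)(=O)N(C)C)cc1C#Cc1cc(Cl)ccc1OCC(=O)O` - 0.004

Going by the values given here, in an ADME assay on a cell-free system (plasma, Homo sapiens) (a higher number here means a larger unbound share of the compound, a lower number a smaller unbound share), compound 1 gives 0.009 and holds the higher of the two numbers measured so far. The next compound to be measured is compound 3 `CS(=O)(=O)c1ccc(F)c(C#Cc2cc(Cl)ccc2OCC(=O)O)c1`, which has methyl in place of dimethylamino on a sulfonyl sulfur and otherwise matches compound 1. Among the compounds with values here, no measured step involves this change, so the evidence is indirect. Within the data shown here, the only guide is compound 2, a change made elsewhere, which gave a 2.3-fold lower number from compound 1 to compound 2 (0.35 log units; beyond the scatter) and so shows the size one change has reached here. The data give no direction for the new change, so only a slight upward lean is expected in this assay. The expected step is a 1.3-fold higher number from compound 1 to compound 3 (0.12 log units; within the scatter) and no larger than the measured one. For compound 3 the estimate is 0.012, with an expected range from 0.005 to 0.025 around it.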

Compound 3, unbound fraction: 0.013
Compound 3: middle estimate off by 1.1-fold (0.03 log units), on the low side; measured number inside the range.
By their numbers in this assay, from the lowest: compound 2; then compounds 1 and 3 (each within the scatter of the next).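

In this assay, going by these compounds alone, the first look at this sulfonyl sulfur shows that exchanging dimethylsulfamoyl for methylsulfonyl gives a 1.4-fold higher number from compound 1 to compound 3 (0.16 log units; within the scatter) and so stays within the scatter. The earlier step on the aromatic carbon, a 2.3-fold lower number from compound 1 to compound 2 (0.35 log units; beyond the scatter), lay beyond the scatter, so in this small set a change at the sulfonyl sulfur need not move the unbound share as clearly as one on that carbon. No separate measurement here offers any explanation for this result.

On these data alone, it remains open whether other groups on the sulfonyl sulfur, such as ethyl or an unsubstituted amine, would also stay within the scatter of compound 1. As far as these compounds go, it is equally open whether methylsulfonyl would give a similar step in compound 2, where methyl stands in place of fluoro.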